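Swapping a Halogenated Phenyl on a Fused Ring Core

The source may report more compounds than this note shows. Statements on the series, on what has been measured and on what is new or still open speak of the compounds shown alone.

Of the compounds shown here, three have been tested in a functional assay on KB3 cells (Homo sapiens) for antiproliferative activity, read by MTT assay, with a stated time of 96 h; on this read-out higher numbers stand for weaker inhibition and lower numbers for stronger inhibition. Compound 1 `C=C(C)[C@H]1CC(=O)C(C)=C2[C@@H](C(=O)OCC)O[C@@H](c3cccc(Cl)c3Cl)[C@@H]21` gives 5000 nM. Compound 3 `C=C(C)[C@H]1CC=C(C)[C@@]2(O)[C@@H]1[C@H](c1cccc(Cl)c1Cl)O[C@@H]2C(=O)OCC` gives 5000 nM, a number level with compound 1 at the digits shown. Compound 2 `C=C(C)[C@H]1CC=C(C)[C@@]2(O)[C@@H]1[C@H](c1ccccc1Br)O[C@@H]2C(=O)OCC` gives 20000 nM. Compound 3 and compound 2 share one core and differ only in the group on a saturated ring carbon (2-bromophenyl in place of 2,3-dichlorophenyl on a saturated ring carbon). That swap produced a 4.0-fold higher number from compound 3 to compound 2 (0.60 log units; beyond the scatter).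

Compound 1 and compound 3 carry different cores; how the two cores differ is not broken down here. Compound 4 `C=C(C)[C@H]1CC(=O)C(C)=C2[C@@H](C(=O)OCC)O[C@@H](c3ccccc3Br)[C@@H]21` stands to compound 1 as compound 2 stands to compound 3, through the change (2-bromophenyl in place of 2,3-dichlorophenyl on a saturated ring carbon). Among the compounds with values here, the surroundings are not identical: in compound 3 the ring carbon also lies two ring bonds from the ring atom that bears a hydroxy group, which has no counterpart in compound 1, so this is the same kind of change rather than the same change.

Resting on the weakening seen across a 4.0-fold higher number from compound 3 to compound 2 (0.60 log units; beyond the scatter), a step of similar size, a 4.0-fold higher number from compound 1 to compound 4 (0.60 log units; beyond the scatter), is expected in this assay. Compound 4 is estimated at 20000 nM, most likely between 8000 nM and 50000 nM.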

Compound 4, half-maximal inhibitory concentration: 70000 nM
Estimate against measurement, compound 4: 3.5-fold (0.54 log units) below; the whole stated range lies below it.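

In this assay, 2-bromophenyl in place of 2,3-dichlorophenyl raised the number on both cores, so the direction of the change carried over, but its size did not: on the core of compound 1 the step was a 14-fold higher number from compound 1 to compound 4 (1.15 log units; beyond the scatter). Set side by side, the two steps differ by more than the usual scatter of repeated measurements: the same change on two cores in this assay, a 4.0-fold higher number (0.60 log units; beyond the scatter) from compound 3 to compound 2 and a 14-fold higher number (1.15 log units; beyond the scatter) from compound 1 to compound 4, 3.5-fold (0.54 log units) apart, beyond the scatter of two such steps

So the core in which this swap is made matters for how much inhibition is lost, but these two pairs do not show which difference between the cores is responsible, and they give no rule for predicting the size of the step on any other core.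

From the compounds shown here alone, it remains open how an unsubstituted phenyl, a methoxyphenyl or a pyridine ring would behave on this saturated ring carbon of either core. Also open, going by these compounds, is whether a carboxylic acid or an amide in place of the ethoxycarbonyl group would alter the size of the step.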